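What Happens When Hydroxy Replaces (3-methylphenyl)amino?

This account rests on a few compounds, and the source may have more. Where it says the series, first, only, none or still open, it means among the compounds named here.

In a toxicity assay on HeLa cells (Homo sapiens) for inhibition (a higher number here means a weaker inhibitor of growth, a lower number a stronger inhibitor of growth), compound 1 `Fc1ccc(Nc2nc3nonc3nc2Nc2ccc(F)cc2)cc1` gives 9.4 ug/mL and compound 2 `FC(F)(F)Oc1cccc(Nc2nc3nonc3nc2Nc2cccc(OC(F)(F)F)c2)c1` gives 4.3 ug/mL while compound 3 `Cc1cccc(Nc2nc3nonc3nc2Nc2cccc(OC(F)(F)F)c2)c1` gives 12 ug/mL and so sits within the scatter of compound 1 and clearly higher than compound 2. Compound 4 `Oc1nc2nonc2nc1Nc1cccc(OC(F)(F)F)c1` differs from compound 3 in one place hydroxy in place of (3-methylphenyl)amino on an aromatic carbon with hydroxy in place of (3-methylphenyl)amino on an aromatic carbon. Going by the values given here, only one measured step bears on this: a 2.8-fold higher number from compound 2 to compound 3 (0.45 log units; beyond the scatter) is modest and swaps one small group for another. Among the compounds with values here, no measured pair shows the loss of a whole ring, so the expectation is loose. A larger move toward a higher number is expected, with a 2.5-fold higher number from compound 3 to compound 4 (0.40 log units; beyond the scatter) as the estimated step in this assay for this change. Compound 4 is expected near 30 ug/mL with an estimated range from 9 ug/mL to 100 ug/mL as the upper end.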

Compound 4, concentration for 50% growth inhibition: 24 ug/mL
Beside the measured number, compound 4's estimate is 1.3-fold (0.10 log units) above it; low and high end bracket the measured number.
By their numbers in this assay, from the lowest: compound 2; then compounds 1, 3 and 4 (each within the scatter of the next, the first and the last beyond it).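

In this assay, hydroxy in place of (3-methylphenyl)amino gives a 2.0-fold higher number from compound 3 to compound 4 (0.30 log units; within the scatter) and so removes a whole six-membered aromatic ring without a change beyond the scatter. Going by these compounds alone, each earlier compound carries a ring-bearing amino group at this position, so only this pair shows that growth inhibition in these cells persists without one. Nothing available explains why the loss of that ring leaves the number within the scatter. From the compounds shown here alone, whether an amine or a methoxy group at this position would behave like hydroxy remains open. So does whether hydroxy would give a similar result alongside a different group on the remaining phenyl ring.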